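Bromo phenol to propyl phenol: a step from a limit

This account rests on a few compounds, and the source may have more. Where it says the series, first, only, none or still open, it means among the compounds named here.

Measured in a functional assay on BV-2 cells (Mus musculus) for inhibition, read by Griess assay, with a stated time of 24 h; a lower number here means a stronger inhibitor, a higher number a weaker inhibitor:
- Compound 1 `Oc1ccc(Br)cc1-c1ccn(Cc2ccccc2)n1`: > 200000 nM (a limit)
- Compound 2 `COc1ccc(Br)cc1-c1ccn(Cc2ccccc2)n1`: > 200000 nM (a limit)

Compound 1 gives > 200000 nM in this assay, and this is a limit of the assay, not a number. Compound 2 gives > 200000 nM, which is likewise a limit. The position of compound 1 is therefore known only as the limit of > 200000 nM in this assay, at which 2 of the 2 values shown sit.

Compound 3 `CCCc1ccc(O)c(-c2ccn(Cc3ccccc3)n2)c1` carries propyl in place of bromo on an aromatic carbon, para to a hydroxy group: propyl in place of bromo on an aromatic carbon. Among the compounds with values here, the only measured step, a step that the two limits leave unreadable from compound 1 to compound 2, changes a different place and yields no size, so no measured step bears directly on this change. The expectation therefore rests on the structural change alone and is weakly founded. A readable result in this assay could only lie on the side of stronger inhibition, and a further limit remains quite possible. The expected step is an at least 2.5-fold lower number from compound 1 to compound 3 (0.39 log units; beyond the scatter). For compound 3 the estimated value is 80000 nM. The expected range for compound 3 runs from 15000 nM to 200000 nM.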

Compound 3, half-maximal inhibitory concentration: 116000 nM
Compound 3: middle estimate off by 1.5-fold (0.16 log units), on the low side; the measured number falls inside the stated range.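

In this assay, within the data shown here, propyl in place of bromo on an aromatic carbon, para to a hydroxy group, gives an at least 1.7-fold lower number from compound 1 to compound 3 (0.23 log units; that floor lies within the scatter), and this position is the first place where a change yields a number rather than a limit. Compound 3 at 116000 nM thus gives the series a readable reference point. From the compounds shown here alone, the true size of the step stays unknown, and its smallest possible size does not establish a difference beyond the scatter. The value of compound 1 remains a limit of the assay and not a number: the limit of > 200000 nM in this assay, at which 2 of the 3 values shown sit.

Going by these compounds, the step from compound 1 to compound 2 cannot be read, so the effect of methyl in place of hydrogen on the oxygen remains unknown, and only a pair built on compound 3 could show it as a number. Also open, on these data alone, is how the number responds at the position para to the hydroxy group when propyl gives way to a longer chain such as pentyl, a shorter one such as methyl, an amine or a carboxylic acid.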